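Dropping the phenolic hydroxyl from compound 2

The source may report more compounds than this note shows. Statements on the series, on what has been measured and on what is new or still open speak of the compounds shown alone.

Compound 1, `COc1cc(/C=C2\CC/C(=C\c3ccc([N+](=O)[O-])cc3)C2=O)cc(OC)c1OC`: in a functional assay on HL-60 cells (Homo sapiens) for cytotoxicity (on this read-out higher numbers stand for lower toxicity in this test and lower numbers for higher toxicity in this test), compound 1 gives > 400000 nM, which is a limit of the assay and not a number.
Compound 2, `COc1cc(/C=C2\Cc3ccccc3/C(=C\c3ccc([N+](=O)[O-])cc3)C2=O)ccc1O`: compound 2 gives 950 nM.
Compound 3, `COc1cc(/C=C2\CCC/C(=C\c3ccc([N+](=O)[O-])cc3)C2=O)ccc1O`: compound 3 gives 3400 nM.

Of the two numbers reported, compound 2 has the lowest; its nearest neighbour is compound 3, whose number lies higher by a step beyond the usual scatter. Compound 1 sits only at the limit of > 400000 nM in this assay, at which 1 of the 3 values shown sits.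

Compound 4, `COc1ccc(/C=C2\Cc3ccccc3/C(=C\c3ccc([N+](=O)[O-])cc3)C2=O)cc1`, is not yet measured. It differs from compound 2 in one place: 4-methoxyphenyl in place of 4-hydroxy-3-methoxyphenyl on a double-bonded chain carbon bound to a double-bonded ring carbon. Going by the values given here, no pair of measured compounds differs by this change, so nothing here shows what such a step does. The writer expects the loss of the hydroxyl to move the number of compound 4 upward by a small amount, a step of a 1.6-fold higher number from compound 2 to compound 4 (0.20 log units; within the scatter) that may stay within the scatter. Compound 4 is therefore estimated at 1500 nM, with a range from 500 nM to 6000 nM.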

Compound 4, half-maximal cytotoxic concentration: 4400 nM
Beside the measured number, compound 4's estimate is 2.9-fold (0.47 log units) below it, and the stated range covers the measured number.
By their numbers in this assay, from the lowest: compound 2; then compounds 3 and 4 (each within the scatter of the next). At a limit, above all of these: compound 1.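

In this assay, going by these compounds alone, the change to 4-methoxyphenyl in place of 4-hydroxy-3-methoxyphenyl on a double-bonded chain carbon bound to a double-bonded ring carbon gives a 4.6-fold higher number from compound 2 to compound 4 (0.67 log units; beyond the scatter) and is the only step here that can be read. It lies beyond the usual scatter, so this position on the core of compound 2 is not indifferent to the change, and the direction is toward a higher number, meaning lower toxicity in this test. Nothing shown here gives a measured property that would account for the step, and the only evidence available does not bear on this result.

Within the data shown here, the single step removes the hydroxyl and alters the methoxy pattern together, so it leaves open which of the two carries the difference. On these data alone, how an amine or a carboxylic acid would read on this same carbon also remains open.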